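The source may hold more compounds than are shown below. What is called first, only, known or untested is meant among the compounds shown, and "the series" means these compounds.

Measured in an ADME assay on L929 cells (Mus musculus) for cytotoxicity, read by resazurin assay, with a stated time of 72 h; a higher number here means a weaker inhibitor, a lower number a stronger inhibitor:
compound 1 `OB1OCc2ccc(-n3cc(Sc4ccc(Cl)c(Cl)c4)c4ccccc43)cc21` — > 10 ug/mL
compound 2 `COc1ccc(CNC(=O)c2cccn2-c2ccc3c(c2)B(O)OC3)cc1` — > 10 ug/mL
compound 3 `CC(=O)c1ccn(-c2ccc3c(c2)B(O)OC3)c1` — > 10 ug/mL

The value for compound 1 is a limit of the assay, not a number. The value for compound 2 is likewise a limit. The value for compound 3 is also a limit. Compound 3 therefore stands only at a limit in this assay, as do the two other values shown; all three sit at the limit of > 10 ug/mL in this assay, at which 3 of the 3 values shown sit.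

Compound 4 `CCCC(=O)c1ccn(-c2ccc3c(c2)B(O)OC3)c1` has not yet been measured in this assay. It differs from compound 3 by ethyl in place of hydrogen on a saturated chain carbon bound to a carbonyl carbon. Among the compounds with values here, no measured step between compounds exists to weigh this change. With compound 3 at its limit, no step beyond the scatter is expected in either direction; compound 4 is expected to report only a limit again, the expected step being a step that the limit leaves unreadable from compound 3 to compound 4. The estimate for compound 4 in this assay is 15 ug/mL, between 7 ug/mL and 50 ug/mL.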

Compound 4, half-maximal inhibitory concentration: > 10 ug/mL
Compound 4: only a limit was reported; the forecaster's own chance of this, stated with the estimate: 85%; the middle value lies beyond the limit too.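

Compound 3 and compound 4 both report only a limit, and no step can be read between them. The compounds shown leave open how far each lies beyond the shared limit: the limit of > 10 ug/mL in this assay, at which 4 of the 4 values shown sit.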